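A few compounds are considered here, and "the series" means these few. Any claim that something is new, unique, unknown or untested is made for them only; others in the source may bear on it.

Working notes on the series.

Compound 1 `CCN(CC)CC(=O)OC1CC2(N(C)C)CC(c3ccccc3)C1C(c1ccccc1)C2` and compound 2 `CCN(CC)CC(=O)OC1CC2(N3CCCCC3)CC(c3ccccc3)C1C(c1ccccc1)C2` share a core that carries a diethylamino ester; compound 3 `CN1CCN(CC(=O)N2CCC3(N(C)C)CC(c4ccccc4)C2C(c2ccccc2)C3)CC1` and compound 4 `CN1CCN(CC(=O)N2CCC3(N4CCCCC4)CC(c4ccccc4)C2C(c2ccccc2)C3)CC1` share a different core with an amide and a methylpiperazine. The difference between the two cores is not broken down here.

In an ADME assay on L6 cells (Rattus norvegicus) for cytotoxicity, read by resazurin assay, with a stated time of 72 h (on this read-out higher numbers stand for weaker inhibition and lower numbers for stronger inhibition), compound 1 gives 30100 nM. Among the compounds with values here, compound 2 gives 23900 nM in this assay, and the single change from compound 1 to compound 2 is piperidin-1-yl in place of dimethylamino on a saturated ring carbon. The step it made is a 1.3-fold lower number from compound 1 to compound 2 (0.10 log units; within the scatter).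

In this assay compound 3 gives 195000 nM, the highest of the three numbers recorded, beyond the scatter from both compound 1 and compound 2.

Compound 4 is not yet measured. It differs from compound 3 by piperidin-1-yl in place of dimethylamino on a saturated ring carbon. This is the same kind of change as that from compound 1 to compound 2, not the same: in compound 1 the place has two ring bonds from the ring atom that bears a (((diethylamino)methyl)carbonyl)oxy group and two ring bonds from the ring atom that bears a phenyl group, whereas in compound 3 the place has two ring bonds from two ring atoms that each bear a phenyl group.

Because the earlier step of a 1.3-fold lower number from compound 1 to compound 2 (0.10 log units; within the scatter) stayed within the scatter, the step from compound 3 to compound 4 is expected to be small as well, estimated at a 1.3-fold lower number from compound 3 to compound 4 (0.11 log units; within the scatter), set beside the earlier one. Compound 4 is therefore expected to give about 150000 nM in this assay, estimated between 60000 nM and 350000 nM. This expectation rests on two compounds only and on the high value of compound 3 195000 nM.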

Compound 4, half-maximal inhibitory concentration: 177000 nM
Compound 4: the middle estimate sits 1.2-fold (0.07 log units) below what was measured, within the range that was stated.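

In this assay, piperidin-1-yl in place of dimethylamino on a saturated ring carbon gives a 1.1-fold lower number from compound 3 to compound 4 (0.04 log units; within the scatter), and the two steps for this change can be set side by side: the same change on two cores in this assay, a 1.3-fold lower number (0.10 log units; within the scatter) from compound 1 to compound 2 and a 1.1-fold lower number (0.04 log units; within the scatter) from compound 3 to compound 4, 1.1-fold (0.06 log units) apart, within the scatter of two such steps. Within these two pairs, the change therefore carries from the core of compound 1 to the core of compound 3 without a step beyond the scatter on either core, and without a difference beyond the scatter between the two steps. This does not show that a real effect of a given size transfers, as neither step can be told apart from the scatter, and two pairs in one cell assay say nothing about other cores or other read-outs.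

From the compounds shown here alone, it remains open whether a pyrrolidin-1-yl group, a morpholin-4-yl group or a primary amine on the same saturated ring carbon would also give steps within the scatter on both cores. It also remains open how the diethylamino ester and the amide with its methylpiperazine each contribute to the difference between the two cores, as the compounds shown change these parts only together.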